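Alkyne acid series: methylation of the ring carbinol

The source may report more compounds than this note shows. Statements on the series, on what has been measured and on what is new or still open speak of the compounds shown alone.

Measured compounds and their numbers:
compound 1 `Cc1ccc(S(=O)(=O)N(C)CC(C)C)cc1C#Cc1cc(Cl)ccc1OCC(=O)O`: 4.2 nM
compound 2 `CC1(O)c2ccc(C#Cc3cc(Cl)ccc3OCC(=O)O)cc2S(=O)(=O)C1(C)C`: 28 nM
compound 3 `Cc1ccc(S(=O)(=O)N(C)CCCN(C)C)cc1C#Cc1cc(Cl)ccc1OCC(=O)O`: 287 nM

In an assay on CHO cells for displacement of a labelled ligand from prostaglandin D2 receptor 2 (Homo sapiens), read by scintillation counting (a lower number here means a stronger inhibitor, a higher number a weaker inhibitor), compound 1 gives 4.2 nM, compound 2 gives 28 nM and compound 3 gives 287 nM. Compound 2 therefore stands second highest of the three numbers: compound 1 sits below it by a gap beyond the scatter, compound 3 above it by a gap beyond the scatter. Among the compounds with values here, no single-point step connects compound 2 with either of the other two; it carries a different core from both.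

Within the data shown here, the only measured step that differs in one place is a 68-fold higher number from compound 1 to compound 3 (1.83 log units; beyond the scatter). Among the measured compounds shown here, that change sits on the chain bound to the sulfonamide nitrogen of compound 1, a part that compound 2 does not carry, so it offers no direct precedent for the present question.

Compound 4 `COC1(C)c2ccc(C#Cc3cc(Cl)ccc3OCC(=O)O)cc2S(=O)(=O)C1(C)C` differs from compound 2 by methyl in place of hydrogen on an oxygen on a saturated carbon. For the measured compounds named here, no step among the measured compounds touches this oxygen, so nothing in hand says whether capping it moves the number. Absent such evidence the step is expected to be small and within the scatter, a 1.3-fold higher number from compound 2 to compound 4 (0.10 log units; within the scatter), with a wider range to cover the lack of precedent. Compound 4 is estimated at 35 nM, between 10 nM and 120 nM.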

Compound 4, inhibition constant: 25 nM
Beside the measured number, compound 4's estimate is 1.4-fold (0.15 log units) above it, and the stated range covers the measured number.
By their numbers in this assay, from the lowest: compound 1; then compounds 4 and 2 (each within the scatter of the next); then compound 3.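

Hydroxy to methoxy gives the first measured step at this oxygen on a saturated carbon: in this assay the swap of hydrogen for methyl reads as a 1.1-fold lower number from compound 2 to compound 4 (0.05 log units; within the scatter) and leaves the two compounds level within the scatter. In this core, then, the free hydroxy hydrogen is not needed to keep the number at the level of compound 2, and a single added methyl on the oxygen is accepted without a measurable change in this assay at this position. No measured data are available to explain why the two compounds read alike.

Still open, on these data alone, is whether this tolerance extends beyond methyl, since a longer chain on the same oxygen, such as ethyl or 2-methoxyethyl, might or might not keep the number at this level. Equally open, as far as these compounds go, is what an amine or a fluorine in place of the hydroxy would do on this saturated carbon, or whether a carboxylic acid or an amide carried on a chain from this oxygen would be accepted in the same way.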